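Moving the amine around the ring on a weak scaffold

The compounds below may be only part of what the source reports. "The series", "measured", "known", "first", "only" and "open" are said of these compounds alone.

Among the compounds with values here, compound 2 `Nc1ccc(Nc2nc(-c3cccc(F)c3)nc3ccc(F)cc23)cc1` is the only compound here with a measured number: in a functional assay on U2OS cells (Homo sapiens) for cytotoxicity, read by MTT assay, with a stated time of 48 h (a lower number here means a stronger inhibitor, a higher number a weaker inhibitor), compound 2 gives 44200 nM. Compound 1 `COc1ccccc1Nc1nc(-c2cccc(F)c2)nc2ccc(F)cc12` differs from it only in the group on a nitrogen on an aromatic ring. In this assay compound 1 reaches only a limit of the assay, > 50000 nM, so the step of an at least 1.1-fold lower number from compound 1 to compound 2 (0.05 log units; that floor lies within the scatter) is a floor rather than a measured difference (the limit of > 50000 nM in this assay, at which 1 of the 2 values shown sits). Compound 3 `Nc1cccc(Nc2nc(-c3cccc(F)c3)nc3ccc(F)cc23)c1` is not yet measured; it has the same atoms as compound 2, joined differently: 3-aminophenyl in place of 4-aminophenyl on a nitrogen on an aromatic ring. Within the data shown here, the single measured step concerns a different group and stays within the scatter, so it gives no direction for moving the amine. Compound 3 is therefore expected to stay near compound 2, with an estimated step of a 1.0-fold higher number from compound 2 to compound 3 (0.01 log units; within the scatter). In this assay compound 3 is estimated at 45000 nM, with a range from 15000 nM to 120000 nM. A sizable chance remains that only a limit is reported.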

Compound 3, half-maximal inhibitory concentration: 49700 nM
The estimate for compound 3 lay 1.1-fold (0.04 log units) below the measured number; measured number inside the range.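

In this assay, 3-aminophenyl in place of 4-aminophenyl on the nitrogen gives a 1.1-fold higher number from compound 2 to compound 3 (0.05 log units; within the scatter), so these two placements on the nitrogen cannot be told apart. Within the data shown here, this is the first step between two real numbers rather than a floor, and it shows that this rearrangement of the same atoms, on its own, brings no readable change on the shared core. Compound 1 stands at a limit of the assay, so the step can only be given as a number no higher from compound 1 to compound 3 (the limit leaves the size open), and its size cannot be read: the limit of > 50000 nM in this assay, at which 1 of the 3 values shown sits.

On these data alone, the third placement of the amine, a 2-aminophenyl group on the same nitrogen, remains open. So does the question of whether a different group there, such as a carboxylic acid or a dimethylamino group, would move the number beyond the scatter.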